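Compound 3 and Its 4-Chlorophenyl Counterpart in HeLa Cells

The source may report more compounds than this note shows. Statements on the series, on what has been measured and on what is new or still open speak of the compounds shown alone.

Three compounds have been measured in a functional assay on HeLa cells (Homo sapiens) for cytotoxicity, read by MTT assay, with a stated time of 48 h, tested at 12.5 uM; on this read-out higher numbers stand for a stronger effect at the one concentration tested and lower numbers for a weaker effect:

Compound 1 `CSc1ccc(/C=N/n2c(Cc3ccc(S(C)(=O)=O)cc3)n[nH]c2=S)cc1` gives 27.9%.
Compound 2 `CS(=O)(=O)c1ccc(Cc2n[nH]c(=S)n2/N=C/c2cccnc2)cc1` gives 16.9%.
Compound 3 `CS(=O)(=O)c1ccc(Cc2n[nH]c(=S)n2/N=C/c2ccccc2Cl)cc1` gives 34.7%.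

Compound 3 has the highest of the three numbers. Its nearest neighbour is compound 1, with a step of a number 6.8 percentage points higher from compound 1 to compound 3 (within the scatter), and the furthest is compound 2, with a step of a number 17.8 percentage points higher from compound 2 to compound 3 (beyond the scatter). Compound 4 `CS(=O)(=O)c1ccc(Cc2n[nH]c(=S)n2/N=C/c2ccc(Cl)cc2)cc1` differs from compound 3 by 4-chlorophenyl in place of 2-chlorophenyl on a carbon with a double bond to nitrogen. Among the compounds with values here, no measured step exchanges one chlorophenyl for another; the measured steps swap whole aryl groups, as in a number 11 percentage points lower from compound 1 to compound 2 (beyond the scatter). Therefore the step of a number 3.7 percentage points lower from compound 3 to compound 4 (within the scatter) is expected to lie within the scatter. Compound 4 is estimated at 31%, in the range 17% to 45%.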

Compound 4, a percentage reported as activity, at one concentration (the size of the read-out at that concentration, not a potency): 44.7%
Beside the measured number, compound 4's estimate is 13.7 percentage points below it, and the stated range covers the measured number.
By their numbers in this assay, from the lowest: compound 2; then compounds 1, 3 and 4 (each within the scatter of the next, the first and the last beyond it).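

In this assay, putting 4-chlorophenyl in place of 2-chlorophenyl on the carbon with a double bond to nitrogen gives a number 10 percentage points higher from compound 3 to compound 4 (within the scatter), so this change does not separate the two chlorophenyl groups. Chloro in place of methylsulfanyl on an aromatic carbon gives a number 16.8 percentage points higher from compound 1 to compound 4 (beyond the scatter), and 4-chlorophenyl in place of pyridin-3-yl gives a number 27.8 percentage points higher from compound 2 to compound 4 (beyond the scatter). Nothing given here explains these steps.

The compounds shown leave open how a bromo, methoxy or amino group at that aromatic carbon would read. A single concentration also gives no potency for any of them.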